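The source may hold more compounds than are shown below. What is called first, only, known or untested is meant among the compounds shown, and "the series" means these compounds.

Compound 1 `COc1ccccc1-c1ccc(COCCCCCN2C[C@H](O)[C@@H](O)[C@H](O)[C@H]2CO)cc1` and compound 2 `N#Cc1ccc(-c2ccc(COCCCCCN3C[C@H](O)[C@@H](O)[C@H](O)[C@H]3CO)cc2)cc1` share the same core and differ only in the aromatic ring at the far end of the chain. In an assay on isolated protein for inhibition of Beta-glucosidase (Homo sapiens) (on this read-out lower numbers stand for stronger inhibition and higher numbers for weaker inhibition), compound 1 gives 3 nM, and in this assay compound 2 gives 3 nM. Among the measured compounds shown here, the one step joining them, no change at the digits printed from compound 1 to compound 2 (within the scatter), shows that exchanging one end ring for another left the read-out where it was. Compound 2 therefore stands level with compound 1, and nothing separates the two beyond the scatter of repeated measurement.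

Compound 3 `OC[C@@H]1[C@@H](O)[C@H](O)[C@@H](O)CN1CCCCCOCc1ccc(-c2ccc3c(c2)OCCO3)cc1` changes the same end ring once more: 2,3-dihydro-1,4-benzodioxin-6-yl in place of 4-cyanophenyl on an aromatic carbon. For the measured compounds named here, the only measured step that bears on this, the one from compound 1 to compound 2, was flat, so the expectation for the step from compound 2 to compound 3 in this assay is again no change beyond the scatter, no change at the digits printed from compound 2 to compound 3 (within the scatter). On that basis compound 3 is estimated at 3 nM in this assay, with a likely range from 1.2 nM to 8 nM.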

Compound 3, half-maximal inhibitory concentration: 30 nM
Beside the measured number, compound 3's estimate is 10-fold (1.00 log units) below it; measured number above the stated range.
By their numbers in this assay, from the lowest: compounds 1 and 2 (each within the scatter of the next); then compound 3.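

In this assay, the end ring is not a freely exchangeable part of the molecule: putting 2,3-dihydro-1,4-benzodioxin-6-yl in place of 4-cyanophenyl gives a 10-fold higher number from compound 2 to compound 3 (1.00 log units; beyond the scatter), and putting the same group in place of the 2-methoxyphenyl ring gives a 10-fold higher number from compound 1 to compound 3 (1.00 log units; beyond the scatter). The flat step between the first two compounds therefore does not extend to every end ring, since the two single-ring ends sit level while the end carrying an extra non-aromatic ring stands apart, even though compound 3 still reads 30 nM. Nothing measured here accounts for this rise in the number.

The non-aromatic ring and its oxygen atoms enter together, and the compounds shown cannot tell which of them goes with the higher number. Also open, from the compounds shown here alone, is how this position responds to a plain phenyl ring, to separate methoxy groups with no extra ring, or to an amine or a carboxylic acid on the end ring.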